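The compounds below may be only part of what the source reports. "The series", "measured", "known", "first", "only" and "open" are said of these compounds alone.

Working notes on the series. Going by the values given here, in a functional assay (thoracic aorta) for inhibition, with Rattus norvegicus as the target (on this read-out lower numbers stand for stronger inhibition and higher numbers for weaker inhibition), compound 1 `O=C(O)c1cc(CCCNS(=O)(=O)c2ccccc2)c2cccccc1-2` gives 4800 nM, the highest of the three numbers so far. Compound 2 `O=C(O)c1cc(CCCCCCCNS(=O)(=O)c2ccccc2)c2cccccc1-2` gives 18 nM in this assay; how its core differs from that of compound 1 is not broken down here. Compound 3 `CC(C)c1ccc2c(CCCCCCCNS(=O)(=O)c3ccccc3)cc(C(=O)O)c-2cc1` gives 120 nM, and the step of a 6.7-fold higher number from compound 2 to compound 3 (0.82 log units; beyond the scatter) comes from the change (isopropyl in place of hydrogen on an aromatic carbon).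

Compound 4 `CC(C)c1cccc2c(CCCNS(=O)(=O)c3ccccc3)cc(C(=O)O)c-2c1` is not yet measured. It differs from compound 1 by isopropyl in place of hydrogen on an aromatic carbon, the same change as from compound 2 to compound 3, made here on the core of compound 1. Among the compounds with values here, a comparable weakening is expected, resting on the step of a 6.7-fold higher number from compound 2 to compound 3 (0.82 log units; beyond the scatter), although only one such pair is at hand and the core of compound 1 is not that of compound 2. The expected step is a 5.2-fold higher number from compound 1 to compound 4 (0.72 log units; beyond the scatter). In this assay compound 4 is estimated at 25000 nM, between 6000 nM and 100000 nM.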

Compound 4, half-maximal inhibitory concentration: 7400 nM
For compound 4 the middle estimate is 3.4-fold (0.53 log units) above the measured one; measured number inside the range.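

On the core of compound 1, isopropyl in place of hydrogen on an aromatic carbon gives a 1.5-fold higher number from compound 1 to compound 4 (0.19 log units; within the scatter), so in this assay the change has no readable effect on this core. The size of the step does not carry over between the two cores: the same change on two cores in this assay, a 6.7-fold higher number (0.82 log units; beyond the scatter) from compound 2 to compound 3 and a 1.5-fold higher number (0.19 log units; within the scatter) from compound 1 to compound 4, 4.3-fold (0.64 log units) apart, beyond the scatter of two such steps. With a single pair on each core, this shows a dependence on the core within these four compounds only; it does not show which feature of the core is responsible or what the change would do on a further core.

Going by these compounds, it remains open whether a smaller group, such as methyl or chlorine, on an aromatic carbon would also differ between the two cores. Also open, on these data alone, is how a tetrazole in place of the carboxylic acid would behave on either core.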